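The compounds below may be only part of what the source reports. "The series", "measured", "known", "first", "only" and "open" are said of these compounds alone.

Compound 1 `CN1C[C@H](C(=O)Nc2ccc(Br)cc2)[C@@H](c2ccc(/C=C/C(=O)Nc3ccccc3N)cc2)C1`, in an in vitro ADME assay on microsomes from liver (Mus musculus) for pharmacokinetics, read by LC-MS, with a stated time of 10 min, tested at 1 uM; a higher number here means faster removal of the compound, a lower number slower removal: 16 mL/min/kg
Compound 2 `CN1C[C@H](C(=O)Nc2ccccc2F)[C@@H](c2ccc(/C=C/C(=O)Nc3ccccc3N)cc2)C1`, in this assay: 67 mL/min/kg

Compound 1 has the lower of these two numbers, so it is the more slowly removed. Compound 3 `CN1C[C@H](C(=O)Nc2ccc(F)c(Cl)c2)[C@@H](c2ccc(/C=C/C(=O)Nc3ccccc3N)cc2)C1` keeps the shared core and changes one group: 3-chloro-4-fluorophenyl in place of 4-bromophenyl on an amide-type nitrogen. In words, 3-chloro-4-fluorophenyl stands in place of 4-bromophenyl on an amide-type nitrogen. Within the data shown here, the only measured step that bears on this is a swap at the same place, a 4.2-fold higher number from compound 1 to compound 2 (0.62 log units; beyond the scatter). It shows that this group can shift the number, but its incoming 2-fluorophenyl differs from the group in compound 3, so it is only a rough guide. A step in the same direction, towards faster removal but smaller, is therefore expected in this assay. The estimated change is a 2.2-fold higher number from compound 1 to compound 3 (0.34 log units; beyond the scatter). For compound 3 the expected clearance is 35 mL/min/kg, with an estimated range from 16 mL/min/kg to 75 mL/min/kg.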

Compound 3, clearance: 34 mL/min/kg
For compound 3 the middle estimate is 1.0-fold (0.01 log units) above the measured one; measured number inside the range.
By their numbers in this assay, from the lowest: compound 1; then compounds 3 and 2 (each within the scatter of the next).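

In this assay, a second swap on the amide-type nitrogen also moves the number away from compound 1, with a 2.1-fold higher number from compound 1 to compound 3 (0.33 log units; beyond the scatter), so compound 1 stays the most slowly removed of the three. The remaining step, a 2.0-fold lower number from compound 2 to compound 3 (0.29 log units; within the scatter), does not separate its two compounds, even though 2-fluorophenyl and 3-chloro-4-fluorophenyl carry different halogens. Nothing shown here explains why the 4-bromophenyl compound is cleared more slowly.

As far as these compounds go, all three compounds carry a halogen-bearing phenyl ring at this position, so it remains open whether the halogens matter at all, or whether an unsubstituted phenyl, a methoxyphenyl or a cyclohexyl group would fall near compound 1 or near the other two. From the compounds shown here alone, the effect of changes elsewhere on the shared core also stays open.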